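The source may report more compounds than this note shows. Statements on the series, on what has been measured and on what is new or still open speak of the compounds shown alone.

Three compounds with a shared core carrying a propane-diamine linker have been tested in an ADME assay on HepG2 cells (Homo sapiens) for cytotoxicity, read by luminescence, CellTiter-Glo and ATP content, with a stated time of 72 h; on this read-out lower numbers stand for an effect already at smaller amounts and higher numbers for an effect only at larger amounts of compound. Compound 1 `COc1cccc(CNCCCNc2ccnc3cc(Oc4ccc(Cl)cc4)ccc23)c1O` gives 5700 nM. Compound 2 `CC(C)CCc1ccc2c(NCCCNCc3ccco3)ccnc2c1` gives 11200 nM, a value within the scatter of compound 1. Compound 3 `COc1cccc(CNCCCNc2ccnc3cc(-c4cc(C(F)(F)F)cc(C(F)(F)F)c4)ccc23)c1O` gives 940 nM, a clearly lower number than compound 1 shows, so compound 1 stands second highest of the three. Compound 4 `COc1cccc(CNCCCNc2ccnc3cc(-c4cccc5ccccc45)ccc23)c1O` differs from compound 1 in one place: naphthalen-1-yl in place of 4-chlorophenoxy on an aromatic carbon Since compound 3 sits well below compound 1 after a related exchange of an aryl ether for a directly attached aryl ring, a step downward beyond the scatter is expected here too, estimated as a 2.9-fold lower number from compound 1 to compound 4 (0.45 log units; beyond the scatter). For compound 4 the expected value is 2000 nM, within a range from 700 nM to 6000 nM.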

Compound 4, half-maximal effective concentration: 2520 nM
For compound 4 the middle estimate is 1.3-fold (0.10 log units) below the measured one; low and high end bracket the measured number.
By their numbers in this assay, from the lowest: compound 3; then compound 4; then compounds 1 and 2 (each within the scatter of the next).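

In this assay, putting naphthalen-1-yl in place of 4-chlorophenoxy on this aromatic carbon gives a 2.3-fold lower number from compound 1 to compound 4 (0.35 log units; beyond the scatter) as a modest step beyond the scatter. For the compounds shown here, this is the first single-place comparison, and it shows that the group at this position can shift the cytotoxicity read-out. Nothing available here accounts for the shift. From the compounds shown here alone, whether an amine, a carboxylic acid or a longer carbon chain at this position would move the number further stays open. This single pair also cannot show whether the step would hold with a different group on the linker.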